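Working notes on a four-compound series

The source may hold more compounds than are shown below. What is called first, only, known or untested is meant among the compounds shown, and "the series" means these compounds.

Measured so far in a functional assay on MKN-45 cells (Homo sapiens) for cytotoxicity, read by MTT assay, with a stated time of 48 h; on this read-out higher numbers stand for weaker inhibition and lower numbers for stronger inhibition:
compound 1 `C#CCSc1nnc(C)n1N1C(=O)c2ccccc2C1=O`: > 200000 nM, a limit of the assay
compound 2 `Cc1nnc(SCc2ccccc2Cl)n1N1C(=O)c2ccccc2C1=O`: > 200000 nM, a limit of the assay
compound 3 `COc1cc(-c2nnc(SCc3ccccc3Cl)n2N2C(=O)c3ccccc3C2=O)cc(OC)c1OC`: > 200000 nM, a limit of the assay

Compound 2 and compound 1 differ by ethynyl in place of 2-chlorophenyl on a saturated chain carbon bound to a sulfur. The step that the two limits leave unreadable from compound 2 to compound 1. Compound 2 and compound 3 differ in their cores by 3,4,5-trimethoxyphenyl in place of methyl on an aromatic carbon, and the step that the two limits leave unreadable from compound 2 to compound 3. Every value so far sits at the limit of > 200000 nM in this assay, at which 3 of the 3 values shown sit, so neither change has shown a readable effect in this assay.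

Compound 4 `C#CCSc1nnc(-c2cc(OC)c(OC)c(OC)c2)n1N1C(=O)c2ccccc2C1=O` is still to be measured in this assay. It differs from compound 3 by ethynyl in place of 2-chlorophenyl on a saturated chain carbon bound to a sulfur. Among the compounds with values here, this is the same change as the one from compound 2 to compound 1, now made on the core of compound 3 instead of the core of compound 2; the place of the change is the same word for word in both pairs. Beside the earlier step, which reads a step that the two limits leave unreadable from compound 2 to compound 1, the step from compound 3 to compound 4 is expected to come out as a number no higher from compound 3 to compound 4 (the limit leaves the size open), an expectation that rests on the fact that every measured compound sits at the limit of > 200000 nM in this assay, at which 3 of the 3 values shown sit, and no change so far has moved any compound off it.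

Compound 4 is therefore expected to show 200000 nM, with a range from 100000 nM to 400000 nM, and the assay is most likely to report only a limit again.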

Compound 4, half-maximal inhibitory concentration: > 200000 nM
Compound 4: a limit, no number; the forecaster's own chance of this, stated with the estimate: 85%; the middle value sits exactly at the limit.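

In this assay compound 4 gives > 200000 nM, a limit of the assay and not a number. No step can be read between compound 3 and compound 4, and the series stays at one limit: the limit of > 200000 nM in this assay, at which 4 of the 4 values shown sit. The compounds shown leave open whether ethynyl in place of 2-chlorophenyl, or 3,4,5-trimethoxyphenyl in place of methyl, changes the read-out in this assay at all.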